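This account rests on a few compounds, and the source may have more. Where it says the series, first, only, none or still open, it means among the compounds named here.

Measured compounds:
compound 1, `CCC(=O)c1cc(-c2ccc(F)cc2)n(-c2ccc(S(N)(=O)=O)cc2)c1C` — 29300 nM
compound 2, `NS(=O)(=O)c1ccc(-c2cc(C(=O)C3CC3)nn2-c2ccc(Cl)cc2)cc1` — 25600 nM

In a physicochemical assay for solubility, read by HPLC, in phosphate buffer, measured as kinetic solubility, at pH 7.4 (on this read-out higher numbers stand for higher solubility and lower numbers for lower solubility), compound 1 gives 29300 nM. In this assay compound 2 gives 25600 nM. The two numbers sit within the usual scatter of each other, so compound 2 and compound 1 stand at essentially the same level, and nothing separates them on these readings. Among the measured compounds shown here, the two measured compounds differ in several places at once, so no single-change step is known here.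

Compound 3, `NS(=O)(=O)c1ccc(-c2cc(C(=O)NC3CC3)nn2-c2ccc(Cl)cc2)cc1`, has not yet been measured. It differs from compound 2 in one place: cyclopropylamino in place of cyclopropyl on a carbonyl carbon. The change exchanges cyclopropylcarbonyl for cyclopropylcarbamoyl on a carbonyl carbon whose other neighbour is an aromatic carbon, bringing in one hydrogen-bond donor.

For the measured compounds named here, no measured pair shows what such a change does here, so the expectation rests on compound 2 alone. Compound 3 is expected to differ from compound 2 by about a 1.2-fold higher number from compound 2 to compound 3 (0.07 log units; within the scatter), a step that would not clearly stand out beyond the scatter. For compound 3 the estimated value in this assay is 30000 nM, with a range from 12000 nM to 75000 nM.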

Compound 3, solubility: 72600 nM
Compound 3: middle estimate off by 2.4-fold (0.38 log units), on the low side; the range from low to high includes it.
By their numbers in this assay, from the lowest: compounds 2 and 1 (each within the scatter of the next); then compound 3.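

In this assay, among the compounds shown here, cyclopropylamino in place of cyclopropyl on a carbonyl carbon gives a 2.8-fold higher number from compound 2 to compound 3 (0.45 log units; beyond the scatter) and is the first single-change step that can be read, as compound 1 and compound 2 differ in several places at once and stand at essentially the same level. It shows that this position is not silent: exchanging cyclopropylcarbonyl for cyclopropylcarbamoyl keeps the three-membered carbon ring and brings in one hydrogen-bond donor, and the number moves beyond the usual scatter. Nothing available here explains why the number moves.

The compounds shown leave open whether the step follows the amide hydrogen itself or the nitrogen more generally, a question that a dimethylamino group on the same carbonyl carbon would bear on directly. They also leave open how far the step carries over to other groups there, such as a morpholine, a longer chain on the amide nitrogen, or a carboxylic acid, and whether it would hold on the core of compound 1.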